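Methoxy in place of methyl: the step to compound 3

A few compounds are considered here, and "the series" means these few. Any claim that something is new, unique, unknown or untested is made for them only; others in the source may bear on it.

Measured in a functional assay on MCF-A cells (Homo sapiens) for cytotoxicity; on this read-out higher numbers stand for weaker inhibition of growth and lower numbers for stronger inhibition of growth:
Compound 1 `COc1ccc(C2=C(c3ccc(SC)cc3)CC3CCCN3C2=O)cc1OC(=O)CNC(=O)OC(C)(C)C`: 6000 nM
Compound 2 `COc1ccc(C2=C(c3ccc(SC)cc3)CC3CCCN3C2=O)cc1C`: 400 nM

Compound 2 holds the lower of the two numbers, at 400 nM, and so shows the stronger inhibition of growth. The next compound, compound 3 `COc1ccc(C2=C(c3ccc(SC)cc3)CC3CCCN3C2=O)cc1OC`, is not yet measured. It differs from compound 2 by methoxy in place of methyl on an aromatic carbon, ortho to a methoxy group and meta to a large group.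

Within the data shown here, only one measured step bears on this change, and it bears only loosely. That step, a 15-fold lower number from compound 1 to compound 2 (1.18 log units; beyond the scatter), is large, but it exchanges a far bigger chain for the methyl group. Among the measured compounds shown here, it shows that the group on this aromatic carbon can shift the number in this assay, yet no measured pair compares two small groups there. The expectation therefore starts from compound 2 at 400 nM, with no clear direction of change. The expected step is a 1.1-fold lower number from compound 2 to compound 3 (0.06 log units; within the scatter), and no change beyond the scatter is expected. For compound 3 the estimated value is 350 nM, with an expected range from 100 nM to 1300 nM.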

Compound 3, concentration for 50% growth inhibition: 600 nM
For compound 3 the middle estimate is 1.7-fold (0.23 log units) below the measured one, and the stated range covers the measured number.
By their numbers in this assay, from the lowest: compounds 2 and 3 (each within the scatter of the next); then compound 1.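

In this assay, among these compounds, this result gives the first comparison of two small groups on this aromatic carbon: a 1.5-fold higher number from compound 2 to compound 3 (0.18 log units; within the scatter), so methoxy in place of methyl, which adds an oxygen and a hydrogen-bond acceptor by the count, leaves no difference that can be read on this measure. The long chain of compound 1 now stands apart from two small groups rather than one, with a 10-fold lower number from compound 1 to compound 3 (1.00 log units; beyond the scatter), and here the comparison is made on the same oxygen on an aromatic ring. Nothing in the data at hand accounts for either step.

The compounds shown leave open which part of the chain in compound 1 goes with its higher number, whether the carbonyl joined to the oxygen or the tert-butoxycarbonyl amino end. They also leave open how a hydroxyl, an amine, a carboxylic acid or a longer chain such as ethoxy on this carbon would stand against compound 2 and compound 3, and whether any of these would fall closer to compound 1.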